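This account rests on a few compounds, and the source may have more. Where it says the series, first, only, none or still open, it means among the compounds named here.

In an ADME assay on microsomes from liver (Mus musculus) for metabolic stability (a lower number here means that the compound disappears faster, a higher number that the compound lasts longer), compound 1 `CCC(CC)(c1nnc[nH]1)c1ccc(-c2ccc3cc(F)cc(F)c3c2)[nH]c1=O` gives 1.09 h. Compound 3 `CCn1ncc2c(F)cc(-c3ccc(C(CC)(CC)c4nnc[nH]4)c(=O)[nH]3)cc21` gives > 3 h, which is a limit of the assay. Compound 2 `CC(C)C(Cc1ncc[nH]1)c1ccc(-c2ccc3cccc(F)c3c2)[nH]c1=O` gives < 0.0667 h, also a limit, and it stands at the short-lived end of the three readings. Compound 4 `CC(C)C(Nc1nccs1)c1ccc(-c2ccc3cccc(F)c3c2)[nH]c1=O` differs from compound 2 in one place: (1,3-thiazol-2-yl)amino in place of (1H-imidazol-2-yl)methyl on a saturated chain carbon bound to an aromatic carbon and a saturated chain carbon. Going by the values given here, no measured pair shows the effect of this change. The expectation therefore rests on compound 2, with its limit of < 0.0667 h, since compound 4 keeps the rest of that structure. Little change is expected in this assay, and the estimated step of an at least 1.4-fold higher number from compound 2 to compound 4 (0.17 log units; that floor lies within the scatter) is a small rise that stays near the usual scatter. For compound 4 the estimated half-life is 0.1 h, within an expected range of 0.05 h to 0.4 h.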

Compound 4, half-life: 0.0733 h
The estimate for compound 4 lay 1.4-fold (0.13 log units) above the measured number, within the range that was stated.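

In this assay, going by these compounds alone, (1,3-thiazol-2-yl)amino in place of (1H-imidazol-2-yl)methyl gives the first one-place comparison at this saturated chain carbon: an at least 1.0-fold higher number from compound 2 to compound 4 (0.04 log units; that floor lies within the scatter). Compound 4 gives 0.0733 h, a number rather than a limit. Compound 2 has only a limit, so the step is a floor and its true size cannot be read: the limit of < 0.0667 h in this assay, at which 1 of the 4 values shown sits.

On these data alone, whether a simple amine or a carboxylic acid at this place would give a longer half-life stays open. So does whether the same change would act alike on the core of compound 1.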